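The compounds below may be only part of what the source reports. "The series", "measured", "known", "first", "only" and "open" are said of these compounds alone.

The study concerns permeability in an ADME assay for permeability, using PAMPA, with a stated time of 30 min, at pH 7.4; a lower number here means that the compound crosses the layer more slowly, a higher number that the compound crosses the layer faster. Among the measured compounds shown here, compound 1 `Fc1ccc(Oc2ccc3c(NCCCNCc4ccco4)ccnc3c2)cc1` gives 317 10^-6 cm/s, the highest of the three numbers so far. Compound 2 `COc1cccc(CNCCCNc2ccnc3cc(CCC(C)C)ccc23)c1O` gives 23 10^-6 cm/s. Compound 3 `COc1ccc(F)cc1CNCCCNc1ccnc2cc(CCc3ccccc3)ccc12` gives 23 10^-6 cm/s, level with compound 2 at the digits shown and within the scatter of it, so the two stand together at the low end of the set, while compound 1 sits well above both, beyond the scatter. Compound 4 `COc1ccc(F)cc1CNCCCNc1ccnc2cc(Cc3ccccc3)ccc12` has not yet been measured in this assay; it differs from compound 3 by phenyl in place of benzyl on a saturated chain carbon bound to an aromatic carbon. In this assay the expected step is a 1.2-fold lower number from compound 3 to compound 4 (0.06 log units; within the scatter), that is, no change beyond the scatter in either direction. Compound 4 is therefore estimated at 20 10^-6 cm/s, with a range from 10 10^-6 cm/s to 45 10^-6 cm/s.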

Compound 4, apparent permeability: 23 10^-6 cm/s
The estimate for compound 4 lay 1.2-fold (0.06 log units) below the measured number; measured number inside the range.
By their numbers in this assay, from the lowest: compounds 2, 3 and 4 (each within the scatter of the next); then compound 1.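

In this assay, among the compounds shown here, the pair formed by compound 3 and compound 4 is the first in the set to differ in one place, and phenyl in place of benzyl on a saturated chain carbon bound to an aromatic carbon gives no change at the digits printed from compound 3 to compound 4 (within the scatter) in this single comparison. The same difference, read as phenethyl to benzyl, therefore leaves the number within the scatter here. Nothing measured in the material at hand offers an explanation for this result.

On these data alone, whether an amine, a carboxylic acid or a longer chain at this place would move the number remains open. So does whether this step would read the same with other groups elsewhere on the shared core.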